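This account rests on a few compounds, and the source may have more. Where it says the series, first, only, none or still open, it means among the compounds named here.

Working notes on the series. All compounds were tested for cytotoxicity in a functional assay on HeLa cells (Homo sapiens) for cytotoxicity, read by MTT assay, with a stated time of 72 h; a lower number here means a stronger inhibitor, a higher number a weaker inhibitor. Compound 1 `O=c1cc(CSc2nc3ccccc3s2)oc2ccc(Cl)cc12` gives only the limit of this assay, > 25000 nM. Compound 2 `Cc1ccc2oc(CSc3nc4nc(C)cc(C)n4n3)cc(=O)c2c1` likewise returns a limit, > 25000 nM. Compound 3 `Cc1cc(C)n2nc(SCc3cc(=O)c4cc(Cl)ccc4o3)nc2n1` also yields no number, only > 25000 nM. Between compound 3 and compound 2 the change is methyl in place of chloro on an aromatic carbon, and the step that the two limits leave unreadable from compound 3 to compound 2 cannot be sized because the limit of > 25000 nM in this assay, at which 3 of the 3 values shown sit, leaves both ends unresolved. Compound 4 `Cc1ccc2oc(CSc3nc4ccccc4s3)cc(=O)c2c1` has not been measured; it differs from compound 1 by methyl in place of chloro on an aromatic carbon, the same change at the same place. The difference between the cores of compound 1 and compound 3 is not broken down here. Among the compounds with values here, since every value so far sits at the limit, the step from compound 1 to compound 4 is expected to be flat, a step that the limit leaves unreadable from compound 1 to compound 4. For compound 4 in this assay the expected value is 30000 nM, most likely again a limit rather than a number.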

Compound 4, half-maximal inhibitory concentration: > 25000 nM
Compound 4: only a limit was reported; the forecaster's own chance of this, stated with the estimate: 85%; the middle value lies beyond the limit too.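

No new step can be read between compound 1 and compound 4, because both ends are limits: the limit of > 25000 nM in this assay, at which 4 of the 4 values shown sit. In this assay the compounds shown leave open what methyl in place of chloro on an aromatic carbon does to a readable number.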